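Chloro Added to the 2-Chlorobenzyl Group of Compound 2

A few compounds are considered here, and "the series" means these few. Any claim that something is new, unique, unknown or untested is made for them only; others in the source may bear on it.

Two members of the series have been measured in an ADME assay on HEK-293T cells (Homo sapiens) for antiproliferative activity, read by MTT assay, with a stated time of 48 h, in the presence of a further agent that is not named here; a lower number here means that less compound is tolerated, a higher number that more compound is tolerated. Compound 1 `O=C(NOCc1ccc(Cl)cc1Cl)c1cn(-c2ccccc2)nc1-c1ccccc1` gives 40200 nM. Compound 2 `O=C(NOCc1ccccc1Cl)c1cn(-c2ccccc2)nc1-c1ccc(Cl)cc1` gives 129000 nM, the higher of the two numbers; its nearest neighbour is compound 1, whose number lies lower by a margin beyond the scatter. Going by the values given here, compound 1 and compound 2 differ in two places, so no single step links them; the two values show only that compound 2 is tolerated at the higher concentration.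

Compound 3 `O=C(NOCc1ccc(Cl)cc1Cl)c1cn(-c2ccccc2)nc1-c1ccc(Cl)cc1` has not yet been measured. It differs from compound 2 in one place: chloro in place of hydrogen on an aromatic carbon, turning 2-chlorobenzyl into 2,4-dichlorobenzyl. That 2,4-dichlorobenzyl group is already present in compound 1, and compound 1 gives 40200 nM. The step expected here is a 2.0-fold lower number from compound 2 to compound 3 (0.30 log units; within the scatter), downward and beyond the scatter. Compound 3 is therefore estimated at 65000 nM, with a range from 25000 nM to 170000 nM.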

Compound 3, half-maximal cytotoxic concentration: 46300 nM
Estimate against measurement, compound 3: 1.4-fold (0.15 log units) above, and the stated range covers the measured number.
By their numbers in this assay, from the lowest: compounds 1 and 3 (each within the scatter of the next); then compound 2.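

In this assay, going by these compounds alone, chloro in place of hydrogen on the aromatic carbon para to a large group, turning 2-chlorobenzyl into 2,4-dichlorobenzyl, gives a 2.8-fold lower number from compound 2 to compound 3 (0.45 log units; beyond the scatter) and so provides the first single-place reading at this position, with a modest step beyond the scatter. The same kind of change at a different aromatic carbon, with the 2,4-dichlorobenzyl group held constant, gives a 1.2-fold higher number from compound 1 to compound 3 (0.06 log units; within the scatter) and stays within the scatter, so among these compounds the step beyond the scatter is seen only for the change on the benzyl group. No measurement in hand explains why the two places differ in this result.

Within the data shown here, open is whether the step from 2-chlorobenzyl to 2,4-dichlorobenzyl keeps its size when the other aromatic carbon carries hydrogen rather than chloro, since only one such pair can be read here. Also open, from the compounds shown here alone, is how this position responds to groups other than chloro, such as a methoxy group, an amine or a carboxylic acid, and how the numbers move when the benzyl group gives way to a longer chain.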